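This account rests on a few compounds, and the source may have more. Where it says the series, first, only, none or still open, it means among the compounds named here.

Measured compounds

Compound 1 `Nc1nc(NC2CC2)c2ncn(/C=C3/CC3(CO)CO)c2n1`: in an ADME assay on MOLT-3 cells (Homo sapiens) for cytotoxicity, with a stated time of 7 days (on this read-out lower numbers stand for higher toxicity in this test and higher numbers for lower toxicity in this test), compound 1 gives > 20000 nM, which is a limit of the assay and not a number.
Compound 2 `CC(C)CSc1nc(N)nc2c1ncn2/C=C1/CC1(CO)CO`: in this assay compound 2 gives "not determined" (no result reported).
Compound 3 `CCCOc1nc(N)nc2c1ncn2/C=C1/CC1(CO)CO`: in this assay compound 3 gives > 20000 nM, which is again a limit of the assay.

Compound 3 therefore stands at the limit of this assay, and this is the same limit at which compound 1 sits, while compound 2 offers no number at all. Going by the values given here, the one step that can be drawn between measured compounds, a step that the two limits leave unreadable from compound 1 to compound 3, is unreadable, since both ends of it are limits, and the limit of > 20000 nM in this assay, at which 2 of the 3 values shown sit, is all that the measured values show.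

The step to compound 4 `CCCCCOc1nc(N)nc2c1ncn2/C=C1/CC1(CO)CO` is ethyl in place of hydrogen on a saturated chain carbon, three bonds along the chain from an oxygen on an aromatic ring. Among the compounds with values here, no measured step bears directly on this change: the only step available, from compound 1 to compound 3, is unreadable, and the two values that are known are both limits. The expectation therefore rests on the fact that compound 3 shows no cytotoxicity up to the limit, and the step of a number no higher from compound 3 to compound 4 (the limit leaves the size open) is estimated to stay within the scatter. Compound 4 is expected to give about 20000 nM in this assay, with a range from 6000 nM to 60000 nM.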

Compound 4, half-maximal cytotoxic concentration: > 20000 nM
Compound 4 ended at the assay's limit; the forecaster's own chance of this, stated with the estimate: 65%; the middle value sits exactly at the limit.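

Going by these compounds alone, compound 1, compound 3 and compound 4 each end at a limit of this assay and not at a number, so no new step among them can be read. The compounds shown leave open how the toxicity of these three compares and where a cytotoxic concentration would lie for any of them, as the values reach only this point: the limit of > 20000 nM in this assay, at which 3 of the 4 values shown sit.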